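A few compounds are considered here, and "the series" means these few. Any claim that something is new, unique, unknown or untested is made for them only; others in the source may bear on it.

Compound 1 `CCOc1ccc2oc(/C=C/[S+](C)[O-])cc(=O)c2c1` gives 4900 nM in a functional assay on DLD-1 cells (Homo sapiens) for cytotoxicity, with a stated time of 48 h (a lower number here means a stronger inhibitor, a higher number a weaker inhibitor), the lowest of the three numbers shown, though compound 2 `CCCCCOc1ccc2oc(/C=C/[S+](C)[O-])cc(=O)c2c1` with 6600 nM and compound 3 `C[S+]([O-])/C=C/c1cc(=O)c2cc(F)ccc2o1` with 7000 nM both lie within the scatter of it. Compound 4 `CC(C)CCOc1ccc2oc(/C=C/[S+](C)[O-])cc(=O)c2c1` differs from compound 1 in one place: isopropyl in place of hydrogen on a saturated chain carbon, two bonds along the chain from an oxygen on an aromatic ring. The step that bears most directly on this change is a 1.3-fold higher number from compound 1 to compound 2 (0.13 log units; within the scatter), a lengthening of the same chain at the same place that stayed within the scatter. The steps of a 1.4-fold higher number from compound 1 to compound 3 (0.15 log units; within the scatter) and a 1.1-fold higher number from compound 2 to compound 3 (0.03 log units; within the scatter) exchange the ring substituent instead and were likewise within the scatter. No step beyond the scatter is therefore expected, giving an estimated 1.2-fold higher number from compound 1 to compound 4 (0.09 log units; within the scatter). For compound 4 the expected value in this assay is 6000 nM, with a range from 3000 nM to 12000 nM.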

Compound 4, half-maximal inhibitory concentration: 4100 nM
Compound 4: the middle estimate sits 1.5-fold (0.17 log units) above what was measured; low and high end bracket the measured number.
By their numbers in this assay, from the lowest: compounds 4, 1, 2 and 3 (each within the scatter of the next).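

In this assay the step of a 1.2-fold lower number from compound 1 to compound 4 (0.08 log units; within the scatter) and the step of a 1.6-fold lower number from compound 2 to compound 4 (0.21 log units; within the scatter) both stay within the scatter, so at this place neither the added isopropyl nor the branched chain in place of the straight one separates compound 4 from the ethoxy or pentyloxy compounds. Exchanging fluoro for isopentyloxy, with a 1.7-fold lower number from compound 3 to compound 4 (0.23 log units; within the scatter) as its step, likewise stays within the scatter. Nothing given here accounts for these small steps. The compounds shown leave open whether an amine or a carboxylic acid at the end of the chain, or a much longer chain, would give a step beyond the scatter.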